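A few compounds are considered here, and "the series" means these few. Any claim that something is new, unique, unknown or untested is made for them only; others in the source may bear on it.

Measured so far:
compound 1 `O=C(CCCCCCc1ccccc1)c1ncno1` in an assay on HEK-293T cells for inhibition of diacylglycerol lipase-alpha (Homo sapiens), read by colorimetric assay; on this read-out lower numbers stand for stronger inhibition and higher numbers for weaker inhibition
compound 2 `CS(=O)(=O)c1cnc(C(=O)CCCCCCc2ccccc2)o1` in this assay

In this assay compound 1 gives only a limit, > 10000 nM. In this assay compound 2 also gives only a limit, > 10000 nM. Compound 2 thus sits at the limit of > 10000 nM in this assay, at which 2 of the 2 values shown sit, with no number of its own. Compound 3 `O=C(CCCCCCc1ccccc1)c1ncc(Cl)o1` has not been run in this assay. Its difference from compound 2 is chloro in place of methylsulfonyl on an aromatic carbon. Among the measured compounds shown here, no step between measured compounds exists, so the series gives no size to lean on. The step that the limit leaves unreadable from compound 2 to compound 3 is expected to be none beyond the scatter, most likely another limit. Compound 3 is estimated at 15000 nM, range 3000 nM to 100000 nM.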

Compound 3, half-maximal inhibitory concentration: > 10000 nM
Compound 3: no number, only a limit; the forecaster's own chance of this, stated with the estimate: 75%; the middle value does not contradict the limit.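

In this assay compound 3 gives only a limit, > 10000 nM, so its steps from compound 1 and compound 2, both also limits, cannot be read. The compounds shown leave open how chloro and methylsulfonyl compare, as none yields a number.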